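Shifting the trifluoromethyl group: compound 3 to compound 4

The compounds below may be only part of what the source reports. "The series", "measured", "known", "first", "only" and "open" are said of these compounds alone.

In a functional assay on MDA-MB-231 cells (Homo sapiens) for antiproliferative activity, read by MTT assay, with a stated time of 72 h (a higher number here means a weaker inhibitor, a lower number a stronger inhibitor), compound 1 (`CC1=CC[C@H]2[C@H](CC[C@]2(C)O)C(C)(C)[C@@H]1CC[C@H]1[C@]2(C)CC[C@H](OC(=O)c3ccncc3)C(C)(C)O[C@H]2CC[C@@]1(C)O`) gives 18000 nM and compound 2 (`CC1=CC[C@H]2[C@H](CC[C@]2(C)O)C(C)(C)[C@@H]1CC[C@H]1[C@]2(C)CC[C@H](OC(=O)NCc3ccccc3)C(C)(C)O[C@H]2CC[C@@]1(C)O`) gives 40300 nM, while compound 3 (`CC1=CC[C@H]2[C@H](CC[C@]2(C)O)C(C)(C)[C@@H]1CC[C@H]1[C@]2(C)CC[C@H](OC(=O)c3ccc(C(F)(F)F)cc3)C(C)(C)O[C@H]2CC[C@@]1(C)O`) gives 19500 nM on the same read-out. The 4-(trifluoromethyl)phenyl compound thus stands level with the pyridin-4-yl compound, with a 1.1-fold higher number from compound 1 to compound 3 (0.03 log units; within the scatter) inside the scatter, and apart from the benzylamino compound, with a 2.1-fold lower number from compound 2 to compound 3 (0.32 log units; beyond the scatter) as a modest step. The largest measured step is a 2.2-fold higher number from compound 1 to compound 2 (0.35 log units; beyond the scatter) and it is also modest.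

Compound 4 (`CC1=CC[C@H]2[C@H](CC[C@]2(C)O)C(C)(C)[C@@H]1CC[C@H]1[C@]2(C)CC[C@H](OC(=O)c3ccccc3C(F)(F)F)C(C)(C)O[C@H]2CC[C@@]1(C)O`) carries 2-(trifluoromethyl)phenyl in place of 4-(trifluoromethyl)phenyl on a carbonyl carbon. For the measured compounds named here, no measured step compares these two groups, so the direction of any change cannot be read from the data. The closest guides replace the entire group on that carbonyl carbon, and they amount only to a 1.1-fold higher number from compound 1 to compound 3 (0.03 log units; within the scatter) and a 2.1-fold lower number from compound 2 to compound 3 (0.32 log units; beyond the scatter) in size. No step beyond the scatter is therefore expected in this assay for this exchange. The expected step is a 1.1-fold higher number from compound 3 to compound 4 (0.05 log units; within the scatter) and it is estimated to stay inside the scatter. Compound 4 is estimated at 22000 nM with an expected range of 11000 nM to 45000 nM as a working figure.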

Compound 4, half-maximal inhibitory concentration: 31500 nM
Estimate against measurement, compound 4: 1.4-fold (0.16 log units) below, within the range that was stated.
By their numbers in this assay, from the lowest: compounds 1, 3, 4 and 2 (each within the scatter of the next, the first and the last beyond it).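

Within this assay, moving the trifluoromethyl group from 4-(trifluoromethyl)phenyl to 2-(trifluoromethyl)phenyl (a 1.6-fold higher number from compound 3 to compound 4 (0.21 log units; within the scatter)) is the first exchange in the series that keeps the atoms of the group and changes only how they are joined, and it stays inside the scatter. The 2-(trifluoromethyl)phenyl ester of compound 4 also lies within the scatter of the pyridin-4-yl compound (a 1.8-fold higher number from compound 1 to compound 4 (0.24 log units; within the scatter)) and of the benzylamino compound (a 1.3-fold lower number from compound 2 to compound 4 (0.11 log units; within the scatter)), so it fills the gap between two compounds that are themselves separated by a modest step beyond the scatter. Nothing available explains these small differences or connects them to any property of the groups.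

Still open, from the compounds shown here alone, is whether a phenyl ring carrying a carboxylic acid or an amine in place of trifluoromethyl would give a step beyond the scatter on this carbonyl carbon. Also open, going by these compounds, is whether a longer chain between the carbonyl and the phenyl ring, or a free hydroxyl in place of the ester, would do so.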